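Fluorophenyl to indolyl on the saturated ring carbon

The source may report more compounds than this note shows. Statements on the series, on what has been measured and on what is new or still open speak of the compounds shown alone.

Compound 3 `O=C(CNC(=O)c1ccccc1)NN1C(=O)CSC1c1ccc(F)cc1` gives 2.1 in a physicochemical assay for lipophilicity (on this read-out lower numbers stand for lower lipophilicity and higher numbers for higher lipophilicity), the second highest of three numbers: compound 2 `O=C(CNC(=O)c1ccccc1)NN1C(=O)CSC1c1ccccc1` gives 1.95, and the pair differ by a number 0.15 log units higher from compound 2 to compound 3 (within the scatter), while compound 1 `O=C(CNC(=O)c1ccccc1)NN1C(=O)CSC1c1ccc(Cl)cc1` gives 2.87, lying a number 0.77 log units lower from compound 1 to compound 3 (beyond the scatter). Compound 4 `O=C(CNC(=O)c1ccccc1)NN1C(=O)CSC1c1c[nH]c2ccccc12` differs from compound 3 by 1H-indol-3-yl in place of 4-fluorophenyl on a saturated ring carbon. The measured steps, a number 0.92 log units lower from compound 1 to compound 2 (beyond the scatter) and a number 0.77 log units lower from compound 1 to compound 3 (beyond the scatter), concern only a halogen on the aromatic carbon, so none of them covers an exchange of the whole aromatic group. Among the measured compounds shown here, with no direct precedent, the step to compound 4 is expected to be small, no change at the digits printed from compound 3 to compound 4 (within the scatter), within the scatter or close to it. Compound 4 is therefore estimated at 2.1, in the range 1.5 to 2.7.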

Compound 4, partition coefficient: 1.7
For compound 4 the middle estimate is 0.40 log units above the measured one, within the range that was stated.
By their numbers in this assay, from the lowest: compounds 4, 2 and 3 (each within the scatter of the next, the first and the last beyond it); then compound 1.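

In this assay the exchange of a whole aromatic group on the saturated ring carbon gives a number 0.40 log units lower from compound 3 to compound 4 (beyond the scatter) and a number 1.17 log units lower from compound 1 to compound 4 (beyond the scatter) but only a number 0.25 log units lower from compound 2 to compound 4 (within the scatter) against plain phenyl. Although it brings more heavy atoms and a hydrogen-bond donor, 1H-indol-3-yl thus cannot be told apart from phenyl at this position. Nothing available here accounts for this result. Going by these compounds, what stays open is how 1-methylindol-3-yl, benzofuran-3-yl or a pyridyl would read on this carbon, and whether the step seen with chloro on the phenyl ring carries over to a chloro on the indole.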